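Swapping one aryl ring on a silyl-bearing compound

A few compounds are considered here, and "the series" means these few. Any claim that something is new, unique, unknown or untested is made for them only; others in the source may bear on it.

compound 1 `COc1ccc(C2=C(c3cc(OC)c(OC)c(OC)c3)C(=O)C(OC(C)=O)C2)cc1` gives 18 ug/mL
compound 2 `COc1ccc(OC)c(C2=C(c3cc(OC)c(OC)c(OC)c3)C(=O)CC2O[SiH2]C(C)(C)C)c1` gives 19 ug/mL
compound 3 `COc1ccc(OC)c(C2=C(c3cc(OC)c(OC)c(OC)c3)C(=O)CC2O)c1` gives > 100 ug/mL

In an ADME assay on HEp-2 cells (Homo sapiens) for cytotoxicity, read by MTT assay, with a stated time of 72 h (a higher number here means a weaker inhibitor, a lower number a stronger inhibitor), compound 2 at 19 ug/mL and compound 1 at 18 ug/mL lie within the scatter of each other. Compound 3 shows > 100 ug/mL as a limit of the assay. Compound 4 `COc1cc(C2=C(c3cc(C)c(OC)c(C)c3)C(O[SiH2]C(C)(C)C)CC2=O)cc(OC)c1OC` keeps the silicon-bearing group of compound 2 and differs from it by 4-methoxy-3,5-dimethylphenyl in place of 2,5-dimethoxyphenyl on a double-bonded ring carbon on a double-bonded ring carbon. Among the compounds with values here, the one measured step, an at least 5.2-fold higher number from compound 2 to compound 3 (0.72 log units; beyond the scatter), removes that silicon-bearing group and leaves this ring untouched. Within the data shown here, no measured step changes the ring, so no shift beyond the scatter is expected. The estimated change is a 1.1-fold higher number from compound 2 to compound 4 (0.02 log units; within the scatter) and stays within the scatter. For compound 4 the estimated value is 20 ug/mL with an expected range of 8 ug/mL to 50 ug/mL as the likely span.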

Compound 4, half-maximal inhibitory concentration: 26 ug/mL
Beside the measured number, compound 4's estimate is 1.3-fold (0.11 log units) below it, within the range that was stated.
By their numbers in this assay, from the lowest: compounds 1, 2 and 4 (each within the scatter of the next). At a limit, above all of these: compound 3.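

Within the data shown here, this is the first measured change on this double-bonded ring carbon: 4-methoxy-3,5-dimethylphenyl in place of 2,5-dimethoxyphenyl gives a 1.4-fold higher number from compound 2 to compound 4 (0.14 log units; within the scatter) in this assay and stays within the scatter. With the silicon-bearing group kept, this position takes either aryl ring without a shift beyond the scatter. Nothing in the data at hand accounts for this result.

The compounds shown leave open whether an aryl ring carrying an amine or a carboxylic acid here would move the number beyond the scatter. They also leave open whether the same ring swap would give a similar result on compound 3, which lacks the silicon-bearing group.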